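A few compounds are considered here, and "the series" means these few. Any claim that something is new, unique, unknown or untested is made for them only; others in the source may bear on it.

Three compounds have so far been measured in a functional assay on M21 cells (Homo sapiens) for antiproliferative activity, read by sulforhodamine B assay, with a stated time of 48 h; on this read-out higher numbers stand for weaker inhibition and lower numbers for stronger inhibition:

compound 1, `CN1CCN(c2ccc(S(=O)(=O)Oc3ccc(F)cc3)cc2)C1=O`, > 100000 nM;
compound 2, `CN1CCN(c2ccc(S(=O)(=O)Oc3ccc(Cl)cc3)cc2)C1=O`, 43000 nM;
compound 3, `CCCN1CCN(c2ccc(S(=O)(=O)Oc3cccc(F)c3)cc2)C1=O`, 12000 nM.

For compound 1 the reported value is a limit of the assay and not a number: the limit of > 100000 nM in this assay, at which 1 of the 3 values shown sits. From compound 1 to compound 2 the change is chloro in place of fluoro on an aromatic carbon, and this gave an at least 2.3-fold lower number from compound 1 to compound 2 (0.36 log units; beyond the scatter). Compound 3 has the lowest of the two numbers; its nearest neighbour is compound 2, which is higher by a margin beyond the usual scatter. How the core of compound 1 differs from the core of compound 3 is not broken down here.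

Compound 4, `CCCN1CCN(c2ccc(S(=O)(=O)Oc3cccc(Cl)c3)cc2)C1=O`, has not yet been measured. It differs from compound 3 by chloro in place of fluoro on an aromatic carbon. This is the same kind of change as that from compound 1 to compound 2, but the place is not the same: in compound 2 the chloro sits para to a large group, in compound 4 meta to a large group. Set beside the earlier step, the expected step in this assay is a 2.4-fold lower number from compound 3 to compound 4 (0.38 log units; beyond the scatter), resting on the earlier at least 2.3-fold lower number from compound 1 to compound 2 (0.36 log units; beyond the scatter). Compound 4 is therefore estimated at 5000 nM, with a likely range from 2000 nM to 12000 nM.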

Compound 4, half-maximal inhibitory concentration: 8600 nM
The estimate for compound 4 lay 1.7-fold (0.24 log units) below the measured number, within the range that was stated.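

In this assay, chloro in place of fluoro gave a 1.4-fold lower number from compound 3 to compound 4 (0.14 log units; within the scatter), so on this core the change cannot be told apart from what repeat measurements of one compound would give. The earlier step is less firm than it looks, since it rests on compound 1, whose > 100000 nM is a limit of the assay and not a number. With the halogen also sitting in a different place in the two pairs, these steps do not show that the change carries from one core to the other, and they do not show that it behaves differently on each: the same change on two cores in this assay, an at least 2.3-fold lower number (0.36 log units; beyond the scatter) from compound 1 to compound 2 and a 1.4-fold lower number (0.14 log units; within the scatter) from compound 3 to compound 4; the limit leaves it open whether they differ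

The compounds shown leave open what groups other than these two halogens, such as a methoxy group or an amine, would do at this place on the ring. They also leave open how a longer chain, such as a hexyl chain, on the shared core would affect the number in this assay.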